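Working notes: replacing pyridin-2-yl on the alkynol series

The source may report more compounds than this note shows. Statements on the series, on what has been measured and on what is new or still open speak of the compounds shown alone.

compound 1 `OCCCCC#Cc1ccccc1C#Cc1ccccn1`: 27700 nM
compound 2 `CSc1ccccc1C#Cc1ccccc1C#CCCCCO`: 5800 nM

In a functional assay on LOX IMVI cells (Homo sapiens) for cytotoxicity (on this read-out lower numbers stand for stronger inhibition of growth and higher numbers for weaker inhibition of growth), compound 1 holds the higher of the two numbers, and the gap down to compound 2 lies beyond the scatter. Compound 3 `OCCCCC#Cc1ccccc1C#Cc1cccc(O)c1` has 3-hydroxyphenyl in place of pyridin-2-yl on a triple-bonded carbon. Among the compounds with values here, no measured step covers this change, so the expectation is weakly founded. With compound 1 at 27700 nM and compound 2 at 5800 nM, a move down appears more likely than a move up. The expected size is a 2.3-fold lower number from compound 1 to compound 3 (0.36 log units; beyond the scatter), towards a lower number in this assay. The estimate for compound 3 is 12000 nM, within an expected range from 4000 nM to 35000 nM.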

Compound 3, concentration for 50% growth inhibition: 16700 nM
The estimate for compound 3 lay 1.4-fold (0.14 log units) below the measured number; the range from low to high includes it.
By their numbers in this assay, from the lowest: compound 2; then compounds 3 and 1 (each within the scatter of the next).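

In this assay, within the data shown here, 3-hydroxyphenyl in place of pyridin-2-yl on a triple-bonded carbon gives a 1.7-fold lower number from compound 1 to compound 3 (0.22 log units; within the scatter), the first measured step at this position. Exchanging a ring with one hetero atom for a ring of carbon only, with a hydrogen-bond donor entering, does not separate the two compounds on this read-out. No measurement here offers an explanation for this result. Still open, going by these compounds, is whether an amine or a carboxylic acid in place of the hydroxyl would move the number beyond the scatter.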